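Working notes: from compound 1 to compound 3

The source may hold more compounds than are shown below. What is called first, only, known or untested is meant among the compounds shown, and "the series" means these compounds.

In a functional assay on KB cells (Homo sapiens) for inhibition, read by MTT assay, with a stated time of 24 h, tested at 100 ug/mL (a lower number here means less inhibition of growth, a higher number more inhibition of growth at the concentration tested), compound 1 (`CC(=O)SCCC(CCCCC(=O)O)SC(C)=O`) gives 8.03% and compound 2 (`Cc1cccc(NC(=O)CCCCC(S)CCS)c1`) gives 17.5%; the two values lie within the scatter of each other. Among the compounds with values here, compound 1 therefore stands level with the only other measured compound, and both readings are low for the concentration tested.

Compound 3 (`CC(=O)SCCC(CCCCC(=O)Nc1ccc(Cl)cc1)SC(C)=O`) keeps the core of compound 1 and carries a single change: (4-chlorophenyl)amino in place of hydroxy on a carbonyl carbon. Within the data shown here, no measured pair isolates this change, so the series gives no direct size for it. Among the measured compounds shown here, the only guide is the reading of compound 2 (17.5%), which suggests that the series stays in this low range.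

A modest upward move in this assay is expected, and it may not clear the scatter. The expected step is small (a number 12 percentage points higher from compound 1 to compound 3 (beyond the scatter)) and is an estimate only. For compound 3 the expected reading is 20% (estimated range 8% to 45%).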

Compound 3, percent growth inhibition at one concentration: 72%
Estimate against measurement, compound 3: 52 percentage points below, outside the stated range (above it).
By their numbers in this assay, from the lowest: compounds 1 and 2 (each within the scatter of the next); then compound 3.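

Within the data shown here, exchanging hydroxy for (4-chlorophenyl)amino on a carbonyl carbon gives the first single-change step that can be read: in this assay it amounts to a number 64 percentage points higher from compound 1 to compound 3 (beyond the scatter). The earlier compounds shown here offered no such pair, and their two readings lay within the scatter of each other, so they gave no sign that this position could move the read-out so far. No measured information bears on what lies behind the step.

The step brings in the amide nitrogen, the six-membered aromatic ring and the chlorine together, and the compounds shown do not divide it among them; a phenylamino group without chlorine, or a plain methylamino group on the same carbonyl carbon, would bear on that. Also open, from the compounds shown here alone, is whether the step depends on chlorine itself, which a methoxy or methyl group in its place on the ring would address, and how it behaves at other concentrations, since the read-out here comes from a single one.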